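Bromo for Butoxy on a Methyl-Bearing Ring

The source may report more compounds than this note shows. Statements on the series, on what has been measured and on what is new or still open speak of the compounds shown alone.

Measured compounds:
compound 1, `CCCCOc1ccc(-c2nc3ncccn3c2Nc2ccccc2)cc1`, 100000 nM
compound 2, `Brc1ccc(-c2nc3ncccn3c2Nc2ccccc2)cc1`, > 100000 nM
compound 3, `CCCCOc1ccc(-c2nc3ncccn3c2Nc2ccccc2)c(C)c1`, 23000 nM

In a toxicity assay on A549 cells (Homo sapiens) for cytotoxicity, read by luminescence and CellTiter-Glo, with a stated time of 48 h (on this read-out higher numbers stand for lower toxicity in this test and lower numbers for higher toxicity in this test), compound 1 gives 100000 nM. Compound 2 is recorded only as a limit of the assay, > 100000 nM, and this limit is noted as the limit of > 100000 nM in this assay, at which 1 of the 3 values shown sits. Compound 3 gives 23000 nM, the lowest number among the two that are numbers.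

Two changes connect these compounds. Compound 1 and compound 2 differ by bromo in place of butoxy on an aromatic carbon, and in this assay the result is a number no lower from compound 1 to compound 2 (the limit leaves the size open). Compound 1 and compound 3 differ by methyl in place of hydrogen on an aromatic carbon, and in this assay the result is a 4.3-fold lower number from compound 1 to compound 3 (0.64 log units; beyond the scatter).

Compound 4, `Cc1cc(Br)ccc1-c1nc2ncccn2c1Nc1ccccc1`, has not yet been measured in this assay. It differs from compound 3 by bromo in place of butoxy on an aromatic carbon. This is the same kind of change as that from compound 1 to compound 2, but not the same: around the place of exchange, compound 4 is meta to a methyl group, while in compound 2 the place is only para to a large group.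

Because the change from compound 1 to compound 2 gave a number no lower from compound 1 to compound 2 (the limit leaves the size open), the step from compound 3 to compound 4 is expected to be a 2.6-fold higher number from compound 3 to compound 4 (0.42 log units; beyond the scatter). Compound 4 is therefore estimated at 60000 nM, with a range from 20000 nM to 150000 nM expected.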

Compound 4, half-maximal cytotoxic concentration: 40000 nM
Beside the measured number, compound 4's estimate is 1.5-fold (0.18 log units) above it, within the range that was stated.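

In this assay, bromo in place of butoxy on the methyl-bearing core gives a 1.7-fold higher number from compound 3 to compound 4 (0.24 log units; within the scatter), and this result can be set beside the same change on the core without the methyl group: the same change on two cores in this assay, a number no lower (the limit leaves the size open) from compound 1 to compound 2 and a 1.7-fold higher number (0.24 log units; within the scatter) from compound 3 to compound 4; the limit leaves it open whether they differ. Methyl in place of hydrogen on an aromatic carbon gives an at least 2.5-fold lower number from compound 2 to compound 4 (0.39 log units; beyond the scatter), and this step lowers the number on both cores: the same change on two cores in this assay, a 4.3-fold lower number (0.64 log units; beyond the scatter) from compound 1 to compound 3 and an at least 2.5-fold lower number (0.39 log units; beyond the scatter) from compound 2 to compound 4; the limit leaves it open whether they differ. Compound 2 is recorded at > 100000 nM, which is a limit of the assay and not a number; the two pairs therefore show that the methyl step keeps its direction on both cores, but they do not show that it keeps its size, nor that the bromo exchange has the same size on both.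

The compounds shown leave open how an amine, a carboxylic acid or a chain longer than butoxy would read at the place where butoxy and bromo were exchanged. They also leave open whether either change would carry over in the same way to cores other than these two.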